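One Aryl Swap at the Ring Amine, Expected Effect

A few compounds are considered here, and "the series" means these few. Any claim that something is new, unique, unknown or untested is made for them only; others in the source may bear on it.

Compound 1 `CC(C)(C)c1cc(CCC(=O)NC2CCN(Cc3ccccc3)CC2)cc(C(C)(C)C)c1O`: 70400 nM
Compound 2 `Cc1ccc(CN2CCC(CCNC(=O)/C=C/c3cc(C(C)(C)C)c(O)c(C(C)(C)C)c3)CC2)cc1`: 8900 nM
Compound 3 `CC(C)(C)c1cc(/C=C/C(=O)NCCC2CCN(Cc3ccc(F)cc3F)CC2)cc(C(C)(C)C)c1O`: 12500 nM

In an assay on isolated protein for inhibition of Amine oxidase [flavin-containing] B (Homo sapiens), read by fluorescence, with stated times of 15 min and 20 min (on this read-out higher numbers stand for weaker inhibition and lower numbers for stronger inhibition), compound 3 holds the second highest of the three numbers. Its nearest neighbour is compound 2, from which it differs by a 1.4-fold higher number from compound 2 to compound 3 (0.15 log units; within the scatter), a step within the scatter. Compound 1 gives 70400 nM, a number beyond the scatter from that of compound 3.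

Compound 4 `CC(C)(C)c1cc(/C=C/C(=O)NCCC2CCN(Cc3ccc(C#N)cc3)CC2)cc(C(C)(C)C)c1O` differs from compound 3 by 4-cyanophenyl in place of 2,4-difluorophenyl on a saturated chain carbon bound to an amine nitrogen in a ring. Within the data shown here, the only measured step at that place, a 1.4-fold higher number from compound 2 to compound 3 (0.15 log units; within the scatter), stayed within the scatter, so no step beyond the scatter is expected in this assay, in either direction. Compound 4 is therefore estimated at 12000 nM, within 5000 nM to 30000 nM. That estimate means an expected step of a 1.0-fold lower number from compound 3 to compound 4 (0.02 log units; within the scatter), within the scatter.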

Compound 4, half-maximal inhibitory concentration: 13900 nM
The estimate for compound 4 lay 1.2-fold (0.06 log units) below the measured number; low and high end bracket the measured number.
By their numbers in this assay, from the lowest: compounds 2, 3 and 4 (each within the scatter of the next); then compound 1.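

With a 1.1-fold higher number from compound 3 to compound 4 (0.05 log units; within the scatter) and a 1.6-fold higher number from compound 2 to compound 4 (0.19 log units; within the scatter), three different aryl groups on the saturated chain carbon bound to the ring amine nitrogen now lie within the scatter of one another in this assay. The 4-cyanophenyl group carries a hydrogen-bond acceptor that 2,4-difluorophenyl lacks, and this difference left no step beyond the scatter. No supporting data bear on why these numbers stay so close. Going by these compounds, it remains open whether a phenyl ring carrying an amine or a carboxylic acid, or a longer chain at this place, would produce a step beyond the scatter.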